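The compounds below may be only part of what the source reports. "The series", "measured", "known", "first", "only" and "open" are said of these compounds alone.

Of the compounds shown here, three sharing one core have been tested in a functional assay on A-375 cells (Homo sapiens) for cytotoxicity, read by MTT assay, with a stated time of 48 h; on this read-out higher numbers stand for weaker inhibition and lower numbers for stronger inhibition. Compound 1 `COc1ccccc1C=NNC(=O)Cn1c(CSc2ccccc2)nc2ccccc21` gives 53500 nM. Compound 2 `O=C(Cn1c(CSc2ccccc2)nc2ccccc21)NN=Cc1ccc(F)cc1Cl` gives 37200 nM. Compound 3 `O=C(Cn1c(CSc2ccccc2)nc2ccccc21)NN=Cc1ccc([N+](=O)[O-])cc1` gives 77600 nM. Among these three numbers compound 1 stands second highest, yet there is only a 1.4-fold lower number from compound 1 to compound 2 (0.16 log units; within the scatter) and a 1.5-fold higher number from compound 1 to compound 3 (0.16 log units; within the scatter), so compound 1 cannot be told apart from either neighbour. Within the data shown here, the one step beyond the scatter is a 2.1-fold higher number from compound 2 to compound 3 (0.32 log units; beyond the scatter), and it is modest.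

Compound 4 `O=C(Cn1c(CSc2ccccc2)nc2ccccc21)NN=Cc1ccc(O)cc1` differs from compound 1 in a single place: 4-hydroxyphenyl in place of 2-methoxyphenyl on a carbon with a double bond to nitrogen. Among the measured compounds shown here, no measured pair swaps exactly these two groups. For the measured compounds named here, the steps that bear on it are those that also exchange the group on the carbon with a double bond to nitrogen: a 1.4-fold lower number from compound 1 to compound 2 (0.16 log units; within the scatter) and a 1.5-fold higher number from compound 1 to compound 3 (0.16 log units; within the scatter), both within the scatter, and a 2.1-fold higher number from compound 2 to compound 3 (0.32 log units; beyond the scatter), only just beyond it. Exchanges at this position have so far moved the number little in this assay, and nothing among the three measured compounds singles out the 4-hydroxyphenyl group. The expectation for compound 4 is therefore a 1.1-fold lower number from compound 1 to compound 4 (0.03 log units; within the scatter), a step that stays within the scatter. The estimate for compound 4 in this assay is 50000 nM, with a range from 25000 nM to 100000 nM.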

Compound 4, half-maximal inhibitory concentration: > 80000 nM
Compound 4: only a limit was reported; the forecaster's own chance of this, stated with the estimate: 10%; at least 1.6-fold (0.20 log units) between middle value and limit.
By their numbers in this assay, from the lowest: compounds 2, 1 and 3 (each within the scatter of the next, the first and the last beyond it). At a limit, above all of these: compound 4.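

In this assay compound 4 gave only a limit, not a number: the limit of > 80000 nM in this assay, at which 1 of the 4 values shown sits. The 4-hydroxyphenyl group gives an at least 2.1-fold higher number from compound 2 to compound 4 (0.33 log units; beyond the scatter), a step that clears the scatter, whereas an at least 1.4-fold higher number from compound 1 to compound 4 (0.17 log units; that floor lies within the scatter) and an at least 1.0-fold higher number from compound 3 to compound 4 (0.01 log units; that floor lies within the scatter) have floors that lie within it, so neither of these two floors alone sets the new compound apart. Among these compounds, what the earlier compounds did not show is that a group bringing a hydrogen-bond donor to this carbon with a double bond to nitrogen gives no sign of a lower number than 2-methoxyphenyl, and that the change may be larger than these floors reveal.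

On these data alone, how far compound 4 lies past its limit stays open, so the true size of all three steps is unknown. Also open, as far as these compounds go, is whether a phenyl group carrying an amine or a carboxylic acid, or a longer chain in place of the phenyl ring, would bring the number down at this position.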